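The source may hold more compounds than are shown below. What is called first, only, known or untested is meant among the compounds shown, and "the series" means these compounds.

Measured compounds:

Compound 1 `CCC(C)n1ncn(-c2ccc(N3CCN(c4ccc(OC[C@@H]5COC(c6ccc(Cl)cc6Cl)O5)cc4)CC3)cc2)c1=O` gives 328 nM in a functional assay on HUVEC cells (Homo sapiens), read by scintillation counting and thymidine incorporation, with a stated time of 24 h; a lower number here means a stronger inhibitor, a higher number a weaker inhibitor.
Compound 2 `CCC(C)n1ncn(-c2ccc(N3CCN(c4ccc(OC[C@@H]5CO[C@@](Cc6ccccc6)(c6ccc(Cl)cc6Cl)O5)cc4)CC3)cc2)c1=O` gives 513 nM in this assay.
Compound 3 `CCC(C)n1ncn(-c2ccc(N3CCN(c4ccc(OC[C@@H]5CO[C@@](Cn6ccnc6C(C)C)(c6ccc(Cl)cc6Cl)O5)cc4)CC3)cc2)c1=O` gives 84 nM in this assay.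

Compound 3 has the lowest number of the three in this assay: compound 1 sits a step above it, and compound 2 sits further above it still, both gaps beyond the scatter. For the measured compounds named here, the one step that changes the group on the saturated chain carbon bound to the saturated ring carbon is a 6.1-fold lower number from compound 2 to compound 3 (0.79 log units; beyond the scatter), where a heteroaryl took the place of phenyl.

Compound 4 `CCC(C)n1ncn(-c2ccc(N3CCN(c4ccc(OC[C@@H]5CO[C@@](Cn6nnnc6C)(c6ccc(Cl)cc6Cl)O5)cc4)CC3)cc2)c1=O` is not yet measured. It differs from compound 3 as follows: 5-methyl-1H-tetrazol-1-yl in place of 2-isopropyl-1H-imidazol-1-yl on a saturated chain carbon bound to a saturated ring carbon. That single measured step tells only that an aromatic heterocycle in this position can give a lower number than phenyl; nothing measured compares two heterocycles with each other, and compound 1, with no group there, lies between compound 2 and compound 3. The expectation for compound 4 in this assay is therefore a number near that of compound 3, with a modest step of a 1.8-fold higher number from compound 3 to compound 4 (0.25 log units; within the scatter) allowed in either direction. Compound 4 is estimated at 150 nM, within 50 nM to 450 nM.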

Compound 4, half-maximal inhibitory concentration: 101 nM
For compound 4 the middle estimate is 1.5-fold (0.17 log units) above the measured one, within the range that was stated.
By their numbers in this assay, from the lowest: compounds 3 and 4 (each within the scatter of the next); then compounds 1 and 2 (each within the scatter of the next).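

In this assay two aromatic heterocycles on the saturated chain carbon bound to a saturated ring carbon can now be compared: 5-methyl-1H-tetrazol-1-yl in place of 2-isopropyl-1H-imidazol-1-yl gives a 1.2-fold higher number from compound 3 to compound 4 (0.08 log units; within the scatter), although the two groups differ in ring hetero atoms, heavy atoms and hydrogen-bond acceptors. The lower number relative to phenyl is thus no longer confined to one heterocycle, since 5-methyl-1H-tetrazol-1-yl in place of phenyl gives a 5.1-fold lower number from compound 2 to compound 4 (0.71 log units; beyond the scatter) as well. Nothing measured here explains why these two groups cannot be told apart in this assay.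

The compounds shown leave open whether a non-aromatic group on this carbon, such as a dimethylamine or a carboxylic acid, would give a similar number. They also leave open what the isopropyl and methyl groups contribute, which the unsubstituted 1H-imidazol-1-yl and 1H-tetrazol-1-yl groups could show.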